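The source may report more compounds than this note shows. Statements on the series, on what has been measured and on what is new or still open speak of the compounds shown alone.

Measured compounds:
- compound 1 `Cc1nc(-c2ccc(F)cc2)ccc1C(=O)Nc1ccc2ccn(C)c2c1` gives < 6.5 in an in vitro functional assay on 1321-N1 cells for antagonist activity at transient receptor potential cation channel subfamily V member 1 (Homo sapiens), read by FLIPR and calcium flux (on this read-out lower numbers stand for lower potency and higher numbers for higher potency (the scale is a negative logarithm)), a limit of the assay only
- compound 2 `Cc1nc(-c2ccc(F)cc2)ccc1C(=O)Nc1ccc2c(C)n[nH]c2c1` gives 6.9 in this assay
- compound 3 `O=C(Nc1ccc2cccnc2c1)c1ccc(Cl)nc1` gives < 6.7 in this assay, again a limit rather than a number

Compound 3 therefore stands at a limit: its value < 6.7 marks the edge of the assay and no number is known for it. Within the data shown here, two of the three values shown are such limits, as the limit of < 6.5 in this assay, at which 1 of the 3 values shown sits, and the limit of < 6.7 in this assay, at which 1 of the 3 values shown sits, record, so the series so far carries only one actual number, that of compound 2.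

Compound 4 `O=C(Nc1ccc2cccnc2c1)c1ccc(-c2ccc(Cl)cc2)nc1` is the untested member. Its change from compound 3 is 4-chlorophenyl in place of chloro on an aromatic carbon. Among the measured compounds shown here, no step between two measured compounds is available for this change, so the size must be guessed. For the measured compounds named here, compound 2, the only numbered compound, carries a 4-fluorophenyl at the matching place and gives 6.9. Compound 1, with the same group, sits at a limit, so the aryl group alone does not guarantee a measurable number.

For compound 4 the expected value in this assay is 7, with a range from 6.3 to 7.7. The step of a number at least 0.30 log units higher from compound 3 to compound 4 (that floor lies within the scatter) is thus expected as a modest gain, not far beyond the scatter, and a limit result for compound 4 remains possible.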

Compound 4, negative logarithm of the antagonist equilibrium constant: 7.8
For compound 4 the middle estimate is 0.80 log units below the measured one; measured number outside the range, above it.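

In this assay, 4-chlorophenyl in place of chloro on an aromatic carbon, next to the ring nitrogen, gives a number at least 1.10 log units higher from compound 3 to compound 4 (beyond the scatter). Among these compounds, the earlier compounds offered no step between measured compounds, so this pair is the first to show that a change at this position alone can move the read-out beyond the scatter, although the finding rests on this single pair. Compound 3 stands at a limit, so the printed size is a floor and the true gap remains unknown: the limit of < 6.7 in this assay, at which 1 of the 4 values shown sits.

The compounds shown leave open whether the gain comes from the added six-membered aromatic ring itself or from the chlorine it carries, a question that an unsubstituted phenyl or a 4-methoxyphenyl at the same place would address. As far as these compounds go, it is also open whether a non-aromatic group such as morpholine or a simple amine at this position would match the 4-chlorophenyl, and whether the same change would give a step of similar size on the core of compound 2.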